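This account rests on a few compounds, and the source may have more. Where it says the series, first, only, none or still open, it means among the compounds named here.

Of the compounds shown here, three of this set have been measured in a functional assay on HL-60 cells (Homo sapiens) for cytotoxicity, read by MTT assay, with a stated time of 4 days; a lower number here means a stronger inhibitor, a higher number a weaker inhibitor. For the measured compounds named here, compound 2 `C=C1C(=O)[C@]23C[C@@]1(O)CC[C@H]2c1ccc(O)c(C)c1[C@@H]3Cn1cc(-c2ccccn2)nn1` is the only one that yields a number: in this assay compound 2 gives 1970 nM. Compound 3 `Cc1c(O)ccc2c1[C@H](Cn1cc(-c3ccccn3)nn1)[C@@]13CC(=O)[C@@](C)(CC[C@@H]21)C3` rests on a different core, and the difference between the two cores is not broken down here. In this assay compound 3 gives > 20000 nM, which is a limit of the assay and not a number. Compound 1 `Cc1c(O)ccc2c1[C@H](Cn1cc(-c3ccc(F)cc3)nn1)[C@@]13CC(=O)[C@@](C)(CC[C@@H]21)C3` arises from compound 3 by one change, (4-fluorophenyl in place of pyridin-2-yl on an aromatic carbon). In this assay compound 1 gives > 20000 nM, again a limit and not a number. The step that the two limits leave unreadable from compound 3 to compound 1 therefore cannot be read, because both values sit at the limit of > 20000 nM in this assay, at which 2 of the 3 values shown sit. Compound 4 `C=C1C(=O)[C@]23C[C@@]1(O)CC[C@H]2c1ccc(O)c(C)c1[C@@H]3Cn1cc(-c2ccc(F)cc2)nn1` has not yet been measured; it arises from compound 2 by the same change, (4-fluorophenyl in place of pyridin-2-yl on an aromatic carbon). Going by the values given here, the one earlier instance of this change gives no readable size. The estimated step of a 1.5-fold higher number from compound 2 to compound 4 (0.18 log units; within the scatter) is accordingly expected to be small, with wide uncertainty in either direction. Compound 4 is thus estimated to give 3000 nM in this assay, with an expected range from 800 nM to 15000 nM.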

Compound 4, half-maximal inhibitory concentration: 660 nM
Estimate against measurement, compound 4: 4.5-fold (0.66 log units) above, outside the stated range (below it).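

In this assay, 4-fluorophenyl in place of pyridin-2-yl on an aromatic carbon gives a 3.0-fold lower number from compound 2 to compound 4 (0.47 log units; beyond the scatter), on the core that the two compounds share. The same change on the core of compound 3 cannot be read, because compound 3 and compound 1 both stand at a limit of the assay and not at a number: the limit of > 20000 nM in this assay, at which 2 of the 4 values shown sit. This leaves a single readable instance of the change, so it does not show whether the lower number carries over from one core to the other, and any effect on the core of compound 3 stays hidden behind the limit.

The compounds shown leave open whether the step follows the fluorine or the loss of the ring nitrogen, a question that a plain phenyl in the same place would help to separate. They also leave open how an amine or a carboxylic acid on that phenyl ring would read in this assay.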